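Chloro replaces dimethylamino on the aryl thiosemicarbazone

This account rests on a few compounds, and the source may have more. Where it says the series, first, only, none or still open, it means among the compounds named here.

Compound 1 `CC1=CC[C@H](C(C)(C)N=C=S)CC1` is the isothiocyanate from which compound 2 `CC1=CC[C@H](C(C)(C)NC(=S)N/N=C/c2ccc(O)cc2)CC1` and compound 3 `CC1=CC[C@H](C(C)(C)NC(=S)N/N=C/c2ccc(N(C)C)cc2)CC1` are derived as thiosemicarbazones. In a functional assay on U-251 cells (Homo sapiens) for inhibition, read by sulforhodamine B assay, with a stated time of 48 h (on this read-out lower numbers stand for stronger inhibition of growth and higher numbers for weaker inhibition of growth), compound 1 gives only a limit, > 100000 nM. In this assay compound 2 likewise gives only a limit, > 100000 nM. Compound 3 gives a limit as well, > 100000 nM. The step that the two limits leave unreadable from compound 2 to compound 3 therefore cannot be read, and compound 3 stands at the limit of > 100000 nM in this assay, at which 3 of the 3 values shown sit. Compound 4 `CC1=CC[C@H](C(C)(C)NC(=S)N/N=C/c2ccc(Cl)cc2)CC1` carries the change (chloro in place of dimethylamino on an aromatic carbon). Because a step that the two limits leave unreadable from compound 2 to compound 3 cannot be read, no direction emerges, and all three measured compounds sit at the same limit. Compound 4 is therefore expected to remain near that limit, with the step of a number no higher from compound 3 to compound 4 (the limit leaves the size open) estimated as slight at most. Compound 4 is estimated at 100000 nM, expected to lie between 30000 nM and 300000 nM.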

Compound 4, concentration for total growth inhibition: > 100000 nM
Compound 4: a limit, no number; the forecaster's own chance of this, stated with the estimate: 80%; the middle value lies on the limit itself.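

In this assay compound 4 gives only a limit, > 100000 nM, so the steps from compound 2 and from compound 3 to compound 4 cannot be read. The compounds shown leave open whether hydroxy, dimethylamino and chloro differ at all in their effect on growth: the limit of > 100000 nM in this assay, at which 4 of the 4 values shown sit.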